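The source may report more compounds than this note shows. Statements on the series, on what has been measured and on what is new or still open speak of the compounds shown alone.

Compound 1, `Nc1nc(Cl)c(-c2ccccn2)c(N[C@@H]2C[C@H](CO)[C@@H](O)[C@H]2O)n1`, is measured in an ADME assay on cells (Homo sapiens) for cytotoxicity, read by polymerase chain reaction, with a stated time of 3 days (on this read-out lower numbers stand for higher toxicity in this test and higher numbers for lower toxicity in this test), at > 25000 nM, which is a limit of the assay rather than a number.
Compound 2, `COc1ccc2nc(-c3c(Cl)nc(N)nc3N[C@@H]3C[C@H](CO)[C@@H](O)[C@H]3O)sc2c1`, reaches in this assay only > 25000 nM, again a limit of the assay.
Compound 3, `CCCNc1nc(C)c(-c2nc3ccccc3s2)c(N[C@@H]2C[C@H](CO)[C@@H](O)[C@H]2O)n1`, likewise shows in this assay only > 25000 nM, a limit of the assay.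

So compound 3 stands nowhere in particular among the numbers shown: its value is a limit, and the two other values shown are limits as well, all sitting at the same boundary, (the limit of > 25000 nM in this assay, at which 3 of the 3 values shown sit). For the measured compounds named here, no step between measured compounds is available. Every value is a limit, so there is no measured change on which to lean.

Compound 4, `Cc1nc(NCc2ccccn2)nc(N[C@@H]2C[C@H](CO)[C@@H](O)[C@H]2O)c1-c1nc2ccccc2s1`, has not yet been measured in this assay. It differs from compound 3 in one place: pyridin-2-yl in place of ethyl on a saturated chain carbon bound to a nitrogen on an aromatic ring. With all three measured values at the limit, the step from compound 3 to compound 4 is expected to be none beyond the scatter, a step that the limit leaves unreadable from compound 3 to compound 4, and the result is expected once more to be a limit rather than a number. Compound 4 is therefore estimated at 30000 nM in this assay, within a range of 10000 nM to 100000 nM.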

Compound 4, half-maximal cytotoxic concentration: 13000 nM
Beside the measured number, compound 4's estimate is 2.3-fold (0.36 log units) above it; measured number inside the range.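

In this assay compound 4 is the only compound shown that gives a number, while the other values all sit at one boundary: the limit of > 25000 nM in this assay, at which 3 of the 4 values shown sit. The change of ethyl to pyridin-2-yl on a saturated chain carbon bound to a nitrogen on an aromatic ring reads as an at least 1.9-fold lower number from compound 3 to compound 4 (0.28 log units; that floor lies within the scatter). As far as these compounds go, this place can therefore hold a group with which the read-out comes off the limit, but the true size of the step stays unknown: compound 3 has only a limit, not a number.

The compounds shown leave open whether the ring nitrogen of pyridin-2-yl matters or any larger group would do the same, and a phenyl ring or a longer chain such as butyl at this place would separate the two. From the compounds shown here alone, whether an amine or a carboxylic acid on that chain would return the read-out to the limit also stays open.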